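This account rests on a few compounds, and the source may have more. Where it says the series, first, only, none or still open, it means among the compounds named here.

Values in a functional assay on HCC 2998 cells (Homo sapiens) for antiproliferative activity (on this read-out lower numbers stand for stronger inhibition of growth and higher numbers for weaker inhibition of growth), so far:

- compound 1 `Cc1cc(-c2nc3ccccc3s2)ccc1N` gives > 100000 nM as a limit of the assay and not a number
- compound 2 `Oc1ccc(-c2nc3ccccc3s2)cc1O` gives 6990 nM as a measured number
- compound 3 `COc1ccc(-c2nc3cc(F)ccc3s2)cc1C` gives 540 nM as a measured number

Of the two measured numbers, compound 3 holds the lower one, and the gap up to compound 2 lies beyond the scatter. The next entry is compound 4 `COc1ccc(-c2nc3cc(F)ccc3s2)cc1I`, which carries iodo in place of methyl on an aromatic carbon, ortho to a methoxy group and meta to a large group (iodo in place of methyl on an aromatic carbon).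

Going by the values given here, no two measured compounds differ in one place, so this exchange has no direct measure. The expectation therefore starts from compound 3 at 540 nM and assumes that the read-out stays near that level. No step beyond the scatter is expected, and the slight lean toward stronger inhibition of growth is only a guess. The estimated change is a 1.4-fold lower number from compound 3 to compound 4 (0.13 log units; within the scatter) in this expectation. For compound 4 the estimated value is 400 nM with an expected range from 80 nM to 2500 nM in this assay measurements.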

Compound 4, concentration for 50% growth inhibition: 940 nM
Beside the measured number, compound 4's estimate is 2.4-fold (0.37 log units) below it, and the stated range covers the measured number.
By their numbers in this assay, from the lowest: compounds 3 and 4 (each within the scatter of the next); then compound 2. At a limit, above all of these: compound 1.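

Going by these compounds alone, at this position, on an aromatic carbon ortho to a methoxy group and meta to a large group, iodo in place of methyl gives a 1.7-fold higher number from compound 3 to compound 4 (0.24 log units; within the scatter) in this assay, and this is the first exchange that can be read directly. Within the data shown here, the two compounds therefore cannot be told apart on this read-out, so the position holds either methyl or iodo without a step beyond the scatter, which the earlier compounds, none of them differing from another in one place, could not show. No available measurement bears on why this exchange gives a step of this size.

On these data alone, a single exchange sets no pattern for this position, and whether an amine, a carboxylic acid, a hydroxyl or a longer chain there would keep the read-out at this level remains open. As far as these compounds go, compounds 1 and 2 each differ from compound 3 in more than one place, so the separate contributions of the methoxy group and the fluoro group on the shared core also remain open.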